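The compounds below may be only part of what the source reports. "The series", "measured", "known", "first", "only" and "open" are said of these compounds alone.

Measured so far:
- compound 1, `O=C(/C=C/c1cccc(NC(=O)c2ccccc2Br)c1)c1nc2ccccc2[nH]1`: 1680 nM
- compound 2, `O=C(Nc1cccc(/C=C/C(=O)c2nc3ccccc3[nH]2)c1)c1cccc(Br)c1`: 1560 nM
- compound 3, `O=C(Nc1cccc(/C=C/C(=O)c2nc3ccccc3[nH]2)c1)c1ccc(Br)cc1`: 2230 nM

All three were tested in a functional assay on HCT-116 cells (Homo sapiens) for antiproliferative activity, read by MTT assay, with a stated time of 48 h; a higher number here means a weaker inhibitor, a lower number a stronger inhibitor. The steps of a 1.1-fold lower number from compound 1 to compound 2 (0.03 log units; within the scatter) and a 1.4-fold higher number from compound 2 to compound 3 (0.16 log units; within the scatter) both lie within the scatter, as does a 1.3-fold higher number from compound 1 to compound 3 (0.12 log units; within the scatter), so compound 2 sits at the low end of three numbers that cannot be told apart; moving the bromine around the ring made no difference that the assay can resolve.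

Compound 4, `Cc1cc(C)cc(C(=O)Nc2cccc(/C=C/C(=O)c3nc4ccccc4[nH]3)c2)c1`, takes a different kind of step from compound 2: 3,5-dimethylphenyl in place of 3-bromophenyl on a carbonyl carbon. For the measured compounds named here, none of the measured steps exchanges the bromine for a pair of methyl groups, so no step bears on this change directly. What the three steps do show is that the ring on the carbonyl carbon tolerated every bromine placement tried without a shift beyond the scatter. On that footing, the expected step of a 1.2-fold higher number from compound 2 to compound 4 (0.06 log units; within the scatter) is none beyond the scatter, with a wide range to allow for the untested substitution. Compound 4 is therefore estimated at 1800 nM, between 700 nM and 4500 nM.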

Compound 4, half-maximal inhibitory concentration: 1550 nM
Compound 4: middle estimate off by 1.2-fold (0.06 log units), on the high side, and the stated range covers the measured number.
By their numbers in this assay, from the lowest: compounds 4, 2, 1 and 3 (each within the scatter of the next).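

In this assay the 3,5-dimethylphenyl group, which carries no bromine, gives the steps of a 1.0-fold lower number from compound 2 to compound 4 (0.00 log units; within the scatter) and a 1.4-fold lower number from compound 3 to compound 4 (0.16 log units; within the scatter) and a 1.1-fold lower number from compound 1 to compound 4 (0.03 log units; within the scatter) against the three bromophenyl compounds. The earlier compounds shown here showed only that a single bromine could sit anywhere on this ring, whereas these steps show that replacing it with two methyl groups also leaves the number inside the scatter, so all four compounds remain indistinguishable. Nothing available explains why this place on the carbonyl carbon responds so little to these changes.

Every group shown here is a phenyl ring bearing only bromine or methyl. Going by these compounds, it remains open whether an amine or a carboxylic acid on this ring, or a longer chain in place of the ring, would move the number beyond the scatter.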